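This account rests on a few compounds, and the source may have more. Where it says the series, first, only, none or still open, it means among the compounds named here.

In a functional assay on PC-3 cells (Homo sapiens) for cytotoxicity, read by MTT assay, with a stated time of 72 h (a higher number here means a weaker inhibitor, a lower number a stronger inhibitor), compound 1 (`COc1cc2ncnc(Nc3ccc(F)c(Cl)c3)c2cc1NC(=O)N/N=C/c1ccc(F)cc1`) gives 36500 nM, compound 2 (`COc1cc2ncnc(Nc3ccc(F)c(Cl)c3)c2cc1NC(=O)N/N=C/c1ccc(C#N)cc1`) gives 36500 nM and compound 3 (`COc1cc2ncnc(Nc3ccc(F)c(Cl)c3)c2cc1NC(=O)N/N=C/c1ccc(O)cc1O`) gives 29500 nM, so compound 3 stands within the scatter of both others. Compound 4 (`COc1cc2ncnc(Nc3ccc(F)c(Cl)c3)c2cc1NC(=O)N/N=C/c1ccc(O)cc1`) differs from compound 3 by hydrogen in place of hydroxy on an aromatic carbon, turning 2,4-dihydroxyphenyl into 4-hydroxyphenyl. The nearest evidence is a 1.2-fold lower number from compound 1 to compound 3 (0.09 log units; within the scatter) and a 1.2-fold lower number from compound 2 to compound 3 (0.09 log units; within the scatter), with no change at the digits printed from compound 1 to compound 2 (within the scatter) alongside, all within the scatter, though none isolates this hydroxy group. No step beyond the scatter is therefore expected in this assay, and the estimated step is a 1.1-fold higher number from compound 3 to compound 4 (0.04 log units; within the scatter). The estimate for compound 4 is 32000 nM, with an expected range of 15000 nM to 60000 nM.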

Compound 4, half-maximal inhibitory concentration: 16600 nM
Compound 4: middle estimate off by 1.9-fold (0.29 log units), on the high side, and the stated range covers the measured number.
By their numbers in this assay, from the lowest: compounds 4, 3, 1 and 2 (each within the scatter of the next, the first and the last beyond it).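

In this assay, the second hydroxy group of the 2,4-dihydroxyphenyl can go without a step beyond the scatter, as a 1.8-fold lower number from compound 3 to compound 4 (0.25 log units; within the scatter) shows. Hydroxy in place of cyano gives a 2.2-fold lower number from compound 2 to compound 4 (0.34 log units; beyond the scatter) and hydroxy in place of fluoro gives a 2.2-fold lower number from compound 1 to compound 4 (0.34 log units; beyond the scatter) as the only steps beyond the scatter so far, both modest, so the group on this aromatic carbon now makes a small measurable difference. No measured evidence accounts for these steps. From the compounds shown here alone, whether an amine or a carboxylic acid on that carbon would move the number further stays open. So does the effect of a methoxy group in place of the hydroxy.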